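The compounds below may be only part of what the source reports. "The series", "measured", "known", "first", "only" and "open" are said of these compounds alone.

Compound 1 `NCCNc1cc(/C=C/c2ccccc2)nc2ccccc12` is the parent of this small set. In an ADME assay on J774 cells (Mus musculus) for cytotoxicity, read by MTT assay, with a stated time of 48 h (a higher number here means a weaker inhibitor, a lower number a stronger inhibitor), compound 1 gives 4600 nM, the lowest of the two numbers recorded so far. Compound 2 `O=C(CNc1ccccc1)NCCNc1cc(/C=C/c2ccccc2)nc2ccccc12` carries an acyl group on the amine nitrogen, and in this assay compound 2 gives 7800 nM; the step of a 1.7-fold higher number from compound 1 to compound 2 (0.23 log units; within the scatter) is within the scatter. Compound 3 `CCOCC(=O)NCCNc1cc(/C=C/c2ccccc2)nc2ccccc12` differs from compound 1 by (ethoxymethyl)carbonyl in place of hydrogen on an amine nitrogen. Since the only comparable acylation of that amine nitrogen, from compound 1 to compound 2, moved the number within the scatter, a step within the scatter is expected here too, as a 1.3-fold higher number from compound 1 to compound 3 (0.12 log units; within the scatter). Compound 3 is therefore estimated at 6000 nM, between 2500 nM and 14000 nM.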

Compound 3, half-maximal inhibitory concentration: 22200 nM
Compound 3: the middle estimate sits 3.7-fold (0.57 log units) below what was measured; measured number above the stated range.
By their numbers in this assay, from the lowest: compounds 1 and 2 (each within the scatter of the next); then compound 3.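

In this assay, acylation on this amine nitrogen is not always neutral: (ethoxymethyl)carbonyl in place of hydrogen gives a 4.8-fold higher number from compound 1 to compound 3 (0.68 log units; beyond the scatter), whereas the anilino-bearing acyl group of compound 2 stayed within the scatter. The group on the saturated chain carbon bound to the carbonyl carbon therefore counts, with ethoxy in place of anilino giving a 2.8-fold higher number from compound 2 to compound 3 (0.45 log units; beyond the scatter). Nothing available accounts for this difference. As far as these compounds go, whether a methoxy group, a longer alkoxy chain or a dialkylamine on that carbon would give a number nearer compound 2 or compound 3 remains open.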